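A few compounds are considered here, and "the series" means these few. Any claim that something is new, unique, unknown or untested is made for them only; others in the source may bear on it.

Of the compounds shown here, two sharing one core have been tested in a functional assay on the whole organism (strain albino) for inhibition, with Rattus norvegicus as the target, read by paw edema, with stated times of 30 min and 2 h, at a dose of 100 mg/kg by the oral route; on this read-out lower numbers stand for less inhibition and higher numbers for more inhibition at the one dose given (going by the name of the read-out). Compound 1, with the structure `COc1ccc(C2=NN(C(=O)CBr)C(c3c(Cl)cccc3Cl)C2)cc1`, gives 49% in that assay. Compound 2, with the structure `COc1ccc(C2=NN(C(=O)CO[N+](=O)[O-])C(c3c(Cl)cccc3Cl)C2)cc1OC`, gives 49% in this assay. On the digits shown compound 2 stands level with compound 1; the two numbers lie within the scatter of each other, so nothing separates them.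

Compound 3, with the structure `COc1ccc(C2=NN(C(=O)CO[N+](=O)[O-])C(c3c(Cl)cccc3Cl)C2)cc1`, has not yet been measured in this assay. It differs from compound 2 in one place: hydrogen in place of methoxy on an aromatic carbon. Cut one bond further out, the same change reads 3,4-dimethoxyphenyl to 4-methoxyphenyl; a methoxy group leaves and a hydrogen enters on an aromatic carbon ortho to a methoxy group and meta to a large group. Going by the values given here, no measured pair here shows what this change does on its own. The step of a number 1 percentage points lower from compound 2 to compound 3 (within the scatter) is expected to be of no size beyond the scatter, because compound 1 gives 49% and compound 2 gives 49% with both kinds of phenyl present among them. The estimate for compound 3 in this assay is 48%, within a range from 36% to 60%.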

Compound 3, a percentage reported as inhibition, in the whole organism at one dose (the size of the read-out at that dose, not a potency): 42%
Estimate against measurement, compound 3: 6 percentage points above; low and high end bracket the measured number.
By their numbers in this assay, from the lowest: compounds 3, 1 and 2 (each within the scatter of the next).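

In this assay, going by these compounds alone, hydrogen in place of methoxy on an aromatic carbon, ortho to a methoxy group and meta to a large group, gives a number 7 percentage points lower from compound 2 to compound 3 (within the scatter); this is the first reading of that change on its own, and at this one dose it does not separate the 3,4-dimethoxyphenyl from the 4-methoxyphenyl. With the 4-methoxyphenyl held fixed, nitrooxy in place of bromo on a saturated chain carbon bound to a carbonyl carbon gives a number 7 percentage points lower from compound 1 to compound 3 (within the scatter), so this second change cannot be told apart from no effect either. No measurement at hand speaks to what lies behind these numbers.

The compounds shown leave open whether another group on the same aromatic carbon, such as a hydroxy group, a fluorine atom or an amine, would move the number beyond the scatter. On these data alone, it is equally open whether an amine, a carboxylic acid or a longer chain on the chain carbon, in place of bromo or nitrooxy, would do so.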